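The source may report more compounds than this note shows. Statements on the series, on what has been measured and on what is new or still open speak of the compounds shown alone.

Measured compounds in this study:

- compound 1, `CCCn1c(=O)c(S(=O)(=O)c2ccc(F)cc2F)cc2cnc(Nc3ccc4[nH]ccc4c3)nc21`: 1000 nM
- compound 2, `Cn1c(=O)c(S(=O)(=O)c2ccc(F)cc2)cc2cnc(Nc3ccc4[nH]cnc4c3)nc21`: 10000 nM
- compound 3, `Cn1c(=O)c(S(=O)(=O)c2ccc(Cl)cc2)cc2cnc(Nc3cnc4[nH]ccc4c3)nc21`: 5000 nM

All three were tested in a functional assay on K562 cells (Homo sapiens) for inhibition, read by trypan blue exclusion, with a stated time of 72 h; on this read-out lower numbers stand for stronger inhibition and higher numbers for weaker inhibition. Compound 1 gives 1000 nM, the lowest of the three numbers, and so the strongest inhibition seen so far. The nearest of the others is compound 3, whose value of 5000 nM lies higher by a gap beyond the usual scatter, and compound 2, at 10000 nM, lies further still. Compounds 2 and 3 differ from compound 1 in more than one place at once, so no single change among the measured compounds can be read off.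

The next compound is compound 4, `O=c1c(S(=O)(=O)c2ccc(F)cc2F)cc2cnc(Nc3ccc4[nH]ccc4c3)nc2n1C1CCCCC1`, which differs from compound 1 in one place: cyclohexyl in place of propyl on an aromatic nitrogen. Among the measured compounds shown here, nothing among the measured compounds shows what swapping one such chain for a ring on that aromatic nitrogen does in this assay. For the measured compounds named here, with no comparable step to lean on, the expectation is a step of no change at the digits printed from compound 1 to compound 4 (within the scatter) that stays within the scatter, in no particular direction. Compound 4 is therefore estimated at 1000 nM, with a range from 300 nM to 3500 nM.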

Compound 4, half-maximal inhibitory concentration: 10000 nM
Beside the measured number, compound 4's estimate is 10-fold (1.00 log units) below it; measured number above the stated range.
By their numbers in this assay, from the lowest: compound 1; then compounds 3, 2 and 4 (each within the scatter of the next).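

In this assay, the group on this aromatic nitrogen clearly matters: with the rest of the molecule unchanged, cyclohexyl in place of propyl gives a 10-fold higher number from compound 1 to compound 4 (1.00 log units; beyond the scatter), which means weaker inhibition. This is the only single change that can be read among the compounds shown, and it establishes that this position does not treat all carbon-only groups alike, even though neither group carries a hydrogen-bond donor, a hydrogen-bond acceptor or a net charge. No measurement shown here accounts for the loss, so its cause remains unknown.

On these data alone, with only propyl and cyclohexyl to compare on the same background, it remains open whether the drop comes with the ring itself or would also appear with a longer chain such as butyl, and a smaller ring such as cyclopropyl or a chain ending in an amine could fall anywhere relative to these two. Compounds 2 and 3 carry methyl on this nitrogen but also differ elsewhere, so the effect of methyl cannot be read from them.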